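A few compounds are considered here, and "the series" means these few. Any claim that something is new, unique, unknown or untested is made for them only; others in the source may bear on it.

Compound 1, `Cc1ccccc1-c1nc(CN2CCC(C(=O)NCCCN3CCC(C(C)C)CC3)CC2)c(C)o1`, gives 0.147 h in an ADME assay on microsomes from liver (Rattus norvegicus) for metabolic stability, read by LC-MS, using NADPH, at 37 degrees C; a higher number here means that the compound lasts longer, a lower number that the compound disappears faster. Compound 2, `Cc1cccc(-c2nc(CN3CCC(C(=O)NCCCN4C[C@H](C)C[C@H](C)C4)CC3)c(C)o2)c1`, is recorded in this assay only as a limit of the assay, > 0.5 h, so where it stands rests on the limit of > 0.5 h in this assay, at which 1 of the 2 values shown sits, rather than on a number of its own. Compound 3, `Cc1cc(C)cc(-c2nc(CN3CCC(C(=O)NCCCN4C[C@H](C)C[C@H](C)C4)CC3)c(C)o2)c1`, has not yet been measured in this assay. Compound 3 differs from compound 2 by methyl in place of hydrogen on an aromatic carbon. Among the measured compounds shown here, no measured pair in this set shares that change, so the account cannot draw on a comparable step. The expectation for this assay is a small step, none beyond the usual scatter, in either direction, and the result may again come out as a limit rather than a number. Compound 3 is therefore estimated at 0.6 h, with a range from 0.25 h to 1.5 h. The step this estimate means is expected to be a step that the limit leaves unreadable from compound 2 to compound 3.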

Compound 3, half-life: < 0.5 h
Compound 3: only a limit was reported; the forecaster's own chance of this, stated with the estimate: 60%; middle value at least 1.2-fold (0.07 log units) away from the limit.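

Among the compounds shown here, this is the first readable step at this place on the aromatic ring: in this assay, going from 3-methylphenyl to 3,5-dimethylphenyl gives a number no higher from compound 2 to compound 3 (the limit leaves the size open). Compound 3 is recorded only as a limit, < 0.5 h. Compound 2 is also recorded only as a limit, > 0.5 h, so the added methyl brought no readable gain in half-life, and the size of any fall cannot be read.

The compounds shown leave open how large this step really is, since neither compound has a number of its own. They also leave open whether a group other than methyl in the same place, such as a chlorine atom or a methoxy group, would give the same direction in this assay.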